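Swapping butoxy for bromophenylamino on the shared core

This account rests on a few compounds, and the source may have more. Where it says the series, first, only, none or still open, it means among the compounds named here.

Of the compounds shown here, three on one core have been measured in a functional assay on NCI-H1299 cells (Homo sapiens) for antiproliferative activity, read by MTT assay, with a stated time of 72 h; on this read-out lower numbers stand for stronger inhibition and higher numbers for weaker inhibition. Compound 1 `O=C(C1=C(O)C(=O)N(CCCn2ccnc2)C1c1ccc(Br)cc1)c1ccccc1` gives 20000 nM. Compound 2 `CCCCOC1=C(C(=O)c2ccccc2)C(c2ccc(Br)cc2)N(CCCn2ccnc2)C1=O` gives 17100 nM, and compound 3 `O=C(C1=C(Nc2ccc(F)cc2)C(=O)N(CCCn2ccnc2)C1c1ccc(Br)cc1)c1ccccc1` gives 25400 nM. The steps among them are all small: a 1.2-fold lower number from compound 1 to compound 2 (0.07 log units; within the scatter), a 1.3-fold higher number from compound 1 to compound 3 (0.10 log units; within the scatter) and a 1.5-fold higher number from compound 2 to compound 3 (0.17 log units; within the scatter), so the three numbers cannot be told apart beyond the scatter, and compound 2 merely sits among them with no separation from either neighbour.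

Compound 4 `O=C(C1=C(Nc2ccccc2Br)C(=O)N(CCCn2ccnc2)C1c1ccc(Br)cc1)c1ccccc1` has not yet been measured. It differs from compound 2 in one place: (2-bromophenyl)amino in place of butoxy on a double-bonded ring carbon. Going by the values given here, the measured step that bears most directly on this change is the one from compound 2 to compound 3, where butoxy also gave way to an arylamino group, and that step stayed within the scatter at a 1.5-fold higher number from compound 2 to compound 3 (0.17 log units; within the scatter). The step from compound 1 to compound 3, in which hydroxy gave way to an arylamino group, was likewise small at a 1.3-fold higher number from compound 1 to compound 3 (0.10 log units; within the scatter). Among the compounds with values here, there is no measured pair that isolates the position of the bromine on the entering ring, so nothing in these data points to a large shift in either direction.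

Compound 4 is therefore expected to land close to its neighbours, with an estimated 22000 nM (range 9000 nM to 50000 nM), which would mean an expected step of a 1.3-fold higher number from compound 2 to compound 4 (0.11 log units; within the scatter).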

Compound 4, half-maximal inhibitory concentration: 15600 nM
Estimate against measurement, compound 4: 1.4-fold (0.15 log units) above, and the stated range covers the measured number.
By their numbers in this assay, from the lowest: compounds 4, 2, 1 and 3 (each within the scatter of the next).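

In this assay, the place on the double-bonded ring carbon now holds (2-bromophenyl)amino, which brings in a six-membered aromatic ring and a hydrogen-bond donor that butoxy lacks, yet the step stays within the scatter (a 1.1-fold lower number from compound 2 to compound 4 (0.04 log units; within the scatter)) and so does the step from hydroxy (a 1.3-fold lower number from compound 1 to compound 4 (0.11 log units; within the scatter)). The new compound also gives the first measured change of the aryl group on the amine nitrogen, 2-bromophenyl in place of 4-fluorophenyl, and that step too is within the scatter (a 1.6-fold lower number from compound 3 to compound 4 (0.21 log units; within the scatter)), so across hydroxy, butoxy and both arylamino groups this place has shown no difference that can be told from the scatter. No measurement here explains why these changes leave the number where it is.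

The compounds shown leave open whether the kind of halogen or its place on the entering ring matters at all, since this pair changes both at once and plain phenylamino, which would help to separate them, is not among them. They also leave open whether a group of another kind here, such as a carboxylic acid, a basic amine such as piperazine or a chain longer than butoxy, would move the number beyond the scatter.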